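Replacing the silicon group of compound 2

The source may report more compounds than this note shows. Statements on the series, on what has been measured and on what is new or still open speak of the compounds shown alone.

For the measured compounds named here, in a functional assay on SMMC-7721 cells (Homo sapiens) for antiproliferative activity, read by MTT assay, with a stated time of 48 h (a higher number here means a weaker inhibitor, a lower number a stronger inhibitor), compound 2 `CC[Si](CC)(CC)C/C1=C/C[C@](C)(CCC=C(C)C)/C=C/[C@@H](OC(=O)C=C(C)C)[C@](C)(O)/C=C/C1=O` gives 3460 nM, the only true number so far. Compound 1 `CC(C)=CCC[C@]1(C)/C=C/[C@@H](OC(=O)C=C(C)C)[C@](C)(O)/C=C/C(=O)/C(C(=O)O)=C\C1` gives > 10000 nM in this assay, which is a limit of the assay and not a number.

Compound 3 `COCOC/C1=C/C[C@](C)(CCC=C(C)C)/C=C/[C@@H](OC(=O)C=C(C)C)[C@](C)(O)/C=C/C1=O` keeps the rest of compound 2 and changes one side group: a group of 4 heavy atoms (2 carbon, 2 oxygen; no ring) in place of a group of 7 heavy atoms (6 carbon, 1 silicon; no ring), on a saturated chain carbon bound to a double-bonded ring carbon. The silicon-bearing group leaves, and methoxymethoxy enters on a saturated chain carbon bound to a double-bonded ring carbon.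

Going by the values given here, only one measured step bears on this change: an at least 2.8-fold lower number from compound 1 to compound 2 (0.46 log units; beyond the scatter). It replaced a group on that double-bonded ring carbon, so it shows that changes in this part of the molecule can shift the number. However, it did not test methoxymethoxy, and compound 3 does not restore the group of compound 1. The evidence therefore supports only a cautious expectation of no change beyond the usual scatter, with a slight lean towards weaker inhibition. The expected step is a 1.4-fold higher number from compound 2 to compound 3 (0.16 log units; within the scatter). For compound 3 the estimated value is 5000 nM, with an expected range from 1800 nM to 14000 nM.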

Compound 3, half-maximal inhibitory concentration: 3250 nM
The estimate for compound 3 lay 1.5-fold (0.19 log units) above the measured number, within the range that was stated.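

In this assay, replacing the silicon-bearing group with methoxymethoxy on this saturated chain carbon gives a 1.1-fold lower number from compound 2 to compound 3 (0.03 log units; within the scatter), so the number does not move beyond the scatter. Here, a smaller group that carries hydrogen-bond acceptors serves as well as a larger one that carries none, although that rests on this single pair and cannot be taken as a rule for the position. Compound 3 also gives a second comparison with the carboxy group of compound 1, an at least 3.0-fold lower number from compound 1 to compound 3 (0.48 log units; beyond the scatter), and this step can only be stated as a minimum because compound 1 gives a limit of the assay and not a number: the limit of > 10000 nM in this assay, at which 1 of the 3 values shown sits.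

The two uncharged side groups in compound 2 and compound 3 give matching results, but neither shows how this position responds to an amine, a free hydroxyl or a longer carbon chain. From the compounds shown here alone, it also remains open whether any such group would move the number beyond the scatter in either direction, or whether the position tolerates most groups other than carboxy.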